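Swapping 1-hydroxyethyl for cyano on a shared core

A few compounds are considered here, and "the series" means these few. Any claim that something is new, unique, unknown or untested is made for them only; others in the source may bear on it.

Compound 1 `COc1ccc(-c2cc(Cl)c3c(N)ncnn23)cc1N1CCN(C(C)=O)C(C)(C)C1=O`, compound 2 `CC(=O)N1CCN(c2cc(-c3cc(Cl)c4c(N)ncnn34)ccc2Cl)C(=O)C1(C)C` and compound 3 `CC(=O)N1CCN(c2cc(-c3cc(Cl)c4c(N)ncnn34)ccc2C(C)O)C(=O)C1(C)C` share one core. In an ADME assay on a cell-free system (serum, Homo sapiens) for protein binding (on this read-out lower numbers stand for a smaller free fraction and higher numbers for a larger free fraction), compound 1 gives 0.17. For compound 2 the entry is "not determined" (no result reported), so it offers no number to compare. Within the data shown here, compound 3 gives 0.34, which lies within the scatter of compound 1, the only other number available, so the two cannot be ranked.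

Compound 4 `CC(=O)N1CCN(c2cc(-c3cc(Cl)c4c(N)ncnn34)ccc2C#N)C(=O)C1(C)C` is the next to be measured, and its change is cyano in place of 1-hydroxyethyl on an aromatic carbon. Among the measured compounds shown here, only one measured step bears on this carbon, a 2.0-fold higher number from compound 1 to compound 3 (0.30 log units; within the scatter), and it stays within the scatter. For the measured compounds named here, no measured compound carries cyano, so this evidence is thin and the range must stay wide. No step beyond the scatter is therefore expected in this assay. The expected change is a 1.4-fold lower number from compound 3 to compound 4 (0.13 log units; within the scatter). The estimated value for compound 4 is 0.25, with an expected range from 0.12 to 0.45.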

Compound 4, unbound fraction: 0.17
For compound 4 the middle estimate is 1.5-fold (0.17 log units) above the measured one, within the range that was stated.
By their numbers in this assay, from the lowest: compounds 1, 4 and 3 (each within the scatter of the next).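

In this assay the swap of 1-hydroxyethyl for cyano, which removes a hydrogen-bond donor from this aromatic carbon, gives a 2.0-fold lower number from compound 3 to compound 4 (0.30 log units; within the scatter) and so cannot be told apart from repeat-to-repeat noise. Cyano in place of methoxy gives no change at the digits printed from compound 1 to compound 4 (within the scatter) and thus adds a third group to the picture: methoxy, 1-hydroxyethyl and cyano on this carbon all lie within the scatter of one another. No supporting measurement is available to explain this flat result.

From the compounds shown here alone, whether an amine, a carboxylic acid or a longer chain on this carbon would give a step beyond the scatter stays open. The flat picture therefore holds only for these three groups on the shared core, and compound 2 adds no number to it.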